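The compounds below may be only part of what the source reports. "The series", "measured", "known", "first", "only" and "open" are said of these compounds alone.

Compound 1, `NC(=O)Cc1cc(=O)oc2cc(OCc3ccccc3)ccc12`, in an assay for inhibition of Amine oxidase [flavin-containing] B (Rattus norvegicus) (a lower number here means a stronger inhibitor, a higher number a weaker inhibitor), compound 1 gives 200 nM.
Compound 2, `NC(=O)Cc1cc(=O)oc2cc(OCc3cccc(F)c3)ccc12`, compound 2 gives 50 nM.
Compound 3, `NC(=O)Cc1cc(=O)oc2cc(OCc3cccnc3)ccc12`, compound 3 gives 1300 nM.

Compound 3 stands as the weakest inhibitor of the three, with the highest number in this assay; its nearest neighbour is compound 1, reached by a 6.5-fold higher number from compound 1 to compound 3 (0.81 log units; beyond the scatter), and its furthest is compound 2, reached by a 26-fold higher number from compound 2 to compound 3 (1.41 log units; beyond the scatter). Compound 4, `NC(=O)Cc1cc(=O)oc2cc(OCc3ccncc3)ccc12`, has not yet been measured. It differs from compound 3 by pyridin-4-yl in place of pyridin-3-yl on a saturated chain carbon bound to an oxygen on an aromatic ring: the same atoms, joined differently, so only the position of the ring nitrogen moves. Going by the values given here, none of the measured steps changes the position of a ring nitrogen. The two measured steps that touch this ring, a 4.0-fold lower number from compound 1 to compound 2 (0.60 log units; beyond the scatter) and a 6.5-fold higher number from compound 1 to compound 3 (0.81 log units; beyond the scatter), each swap one ring for another and say nothing about moving the nitrogen within the pyridine. Among the compounds with values here, with no step bearing directly on the change, no shift beyond the scatter is expected in this assay, and the estimate for compound 4 is 1300 nM, between 400 nM and 4000 nM, which would mean no change at the digits printed from compound 3 to compound 4 (within the scatter).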

Compound 4, half-maximal inhibitory concentration: 2000 nM
The estimate for compound 4 lay 1.5-fold (0.19 log units) below the measured number; measured number inside the range.
By their numbers in this assay, from the lowest: compound 2; then compound 1; then compounds 3 and 4 (each within the scatter of the next).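

Moving the ring nitrogen at this place on the chain makes no difference that can be read in this assay (a 1.5-fold higher number from compound 3 to compound 4 (0.19 log units; within the scatter)), so the pyridin-3-yl and pyridin-4-yl groups cannot be told apart here. Compound 3 alone could not show whether the loss against the all-carbon rings depended on where the nitrogen sat, but the gap stays wide for the pyridin-4-yl group too (a 10-fold higher number from compound 1 to compound 4 (1.00 log units; beyond the scatter); a 40-fold higher number from compound 2 to compound 4 (1.60 log units; beyond the scatter)), so for these two positions it does not. No measurement shown gives a reason for the loss that comes with a ring nitrogen in either position.

Still open, from the compounds shown here alone, is whether a chloro group on the phenyl ring would match the gain seen with fluoro. Also open, going by these compounds, is how a pyrimidine ring, or a longer chain between the oxygen and the ring, would fare.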